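This account rests on a few compounds, and the source may have more. Where it says the series, first, only, none or still open, it means among the compounds named here.

Compound 2 `Cc1nn(-c2nc(-c3ccc(Cl)c(Cl)c3)c(SC(C)C)s2)c(C(=O)O)c1Cc1ccccc1[N+](=O)[O-]` is one of three compounds tested in a functional assay on BJAB cells (Homo sapiens) for antiproliferative activity, with a stated time of 4 days (a higher number here means that more compound is needed for the effect, a lower number that less compound is needed), where compound 2 gives 20000 nM. For the measured compounds named here, compound 1 `COc1ccc(C)cc1-c1c(C)nn(-c2nc(-c3ccc(Cl)c(Cl)c3)c(SC(C)C)s2)c1C(=O)O` gives 9500 nM in this assay, and the single step between them is a 2.1-fold higher number from compound 1 to compound 2 (0.32 log units; beyond the scatter), so compound 2 carries the higher of the two numbers reported. Compound 3 `Cc1c(-c2cc(Cl)cc(Cl)c2)c(C(=O)O)nn1-c1nc(-c2ccncc2)c(SC(C)C)s1` is reported in this assay as "not active" (no number reported), and no number is given for it. Compound 4 `COc1cc(-c2c(C)nn(-c3nc(-c4ccc(Cl)c(Cl)c4)c(SC(C)C)s3)c2C(=O)O)cc(C(F)(F)F)c1` has not yet been measured. It differs from compound 2 in one place: 3-methoxy-5-(trifluoromethyl)phenyl in place of 2-nitrobenzyl on an aromatic carbon. Going by the values given here, the only measured step that bears on this change is a 2.1-fold higher number from compound 1 to compound 2 (0.32 log units; beyond the scatter), which swapped 2-methoxy-5-methylphenyl for 2-nitrobenzyl at the same carbon and was modest. The incoming 3-methoxy-5-(trifluoromethyl)phenyl resembles the 2-methoxy-5-methylphenyl of compound 1 more closely than it resembles 2-nitrobenzyl, so the present change largely undoes that earlier swap. Because the earlier step was a 2.1-fold higher number from compound 1 to compound 2 (0.32 log units; beyond the scatter), compound 4 is expected to show a step of a 2.0-fold lower number from compound 2 to compound 4 (0.30 log units; within the scatter), a modest fall in the number. The estimate for compound 4 in this assay is 10000 nM, with a range from 4000 nM to 25000 nM, and some chance that, as for compound 3, no number is returned.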

Compound 4, half-maximal effective concentration: 1380 nM
For compound 4 the middle estimate is 7.2-fold (0.86 log units) above the measured one, outside the stated range (below it).
By their numbers in this assay, from the lowest: compound 4; then compound 1; then compound 2.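

At this aromatic carbon of the shared core, the choice of group can matter far more in this assay than the earlier modest step of a 2.1-fold higher number from compound 1 to compound 2 (0.32 log units; beyond the scatter) suggested, as the large step of a 14-fold lower number from compound 2 to compound 4 (1.16 log units; beyond the scatter) shows. Compound 4 is also not simply a return to compound 1, since exchanging 2-methoxy-5-methylphenyl for 3-methoxy-5-(trifluoromethyl)phenyl, both phenyl groups attached directly to that carbon, gives a step beyond the scatter, a 6.9-fold lower number from compound 1 to compound 4 (0.84 log units; beyond the scatter), so the substituents and their places on this phenyl ring also count. No measurement shown gives a reason for the size of either step.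

The last comparison changes the place of the methoxy group and replaces methyl with trifluoromethyl at once, so the share of each change remains unresolved. A plain phenyl, 3-methoxyphenyl or 3-(trifluoromethyl)phenyl at this carbon could separate these contributions, while a benzyl group carrying the same methoxy and trifluoromethyl groups could show how much depends on the carbon link in 2-nitrobenzyl rather than on the groups on its ring.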